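The compounds below may be only part of what the source reports. "The series", "measured", "known", "first", "only" and "open" are said of these compounds alone.

Measured compounds:
- compound 1, `CN(C)C(=O)C(C)(C)COc1nnc(-c2ccc(NC(=O)c3ccc4ccccc4c3)cc2)n1C`, gives 440 nM in an assay on 3T3-L1 cells for inhibition of diacylglycerol O-acyltransferase 1 (Mus musculus); a lower number here means a stronger inhibitor, a higher number a weaker inhibitor
- compound 2, `Cc1ccc(C(=O)Nc2ccc(-c3nnc(SC(C)C(=O)O)n3C)cc2)cc1`, gives > 20000 nM in this assay

Compound 1 is the only one of the two with a measured number in this assay. The value of compound 2 is a limit of the assay, not a number, and it says only that no inhibition was measured up to that point. Among the measured compounds shown here, compound 1 and compound 2 share a core but differ in several places at once, so no single step can be read between them; the two values show only that compound 1 inhibits measurably where compound 2 does not. Compound 3, `Cn1c(OCC(C)(C)C(N)=O)nnc1-c1ccc(NC(=O)c2ccc3ccccc3c2)cc1`, is not yet measured. It differs from compound 1 in one place: amino in place of dimethylamino on a carbonyl carbon. The amide loses its two methyl groups and gains a hydrogen-bond donor. For the measured compounds named here, with no measured pair to set the size of this step, the change from compound 1 to compound 3 in this assay is expected to be small, a 1.1-fold higher number from compound 1 to compound 3 (0.06 log units; within the scatter), with no clear direction. Compound 3 is therefore estimated at 500 nM, within 150 nM to 1800 nM.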

Compound 3, half-maximal inhibitory concentration: 6100 nM
Estimate against measurement, compound 3: 12-fold (1.09 log units) below; the measured number lies above the stated range.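

In this assay, this position on the carbonyl carbon proves sensitive to a small change: amino in place of dimethylamino gives a 14-fold higher number from compound 1 to compound 3 (1.14 log units; beyond the scatter) and nothing else in the structure moves. Among the compounds shown here, compound 1 and compound 2 could not show this, as they differ in several places at once, so this is the first single change that can be read. Compound 3 gives 6100 nM, a measured number, so in this pair the change weakens inhibition but still leaves it detectable.

As far as these compounds go, it stays open whether a methylamino group, which lies between the two groups compared here, or a ring amine such as piperidine on the same carbonyl carbon would restore inhibition or lose more of it. The compounds shown give no reason for the size of this step.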